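Hydroxy to methyl: an expected inactive compound

The compounds below may be only part of what the source reports. "The series", "measured", "known", "first", "only" and "open" are said of these compounds alone.

Within the data shown here, compound 1 `O=S(=O)(Nc1ccc2oc(-c3ccccc3)nc2c1)c1ccccc1O` is one of two compounds measured in an assay on isolated protein for inhibition of malate dehydrogenase, mitochondrial (Sus scrofa), with stated times of 45 min and 30 min; on this read-out lower numbers stand for stronger inhibition and higher numbers for weaker inhibition. In this assay compound 1 gives only a limit of the assay, > 63000 nM. Compound 2 `COc1ccc(S(=O)(=O)Nc2ccc(-c3nc4ccccc4o3)cc2)cc1` likewise gives only a limit, > 63000 nM. Both values sit at the limit (the limit of > 63000 nM in this assay, at which 2 of the 2 values shown sit), so neither compound shows measurable inhibition and no ordering between them is possible. Compound 3 `Cc1ccccc1S(=O)(=O)Nc1ccc2oc(-c3ccccc3)nc2c1` is not yet measured; it differs from compound 1 by methyl in place of hydroxy on an aromatic carbon. Since compound 1 already sits at the limit (the limit of > 63000 nM in this assay, at which 2 of the 2 values shown sit), no step beyond the scatter is expected: a number no higher from compound 1 to compound 3 (the limit leaves the size open). Compound 3 is therefore expected to give 63000 nM, in the range 20000 nM to 200000 nM, most likely again as a limit.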

Compound 3, half-maximal inhibitory concentration: > 63000 nM
Compound 3 was reported as a limit; the forecaster's own chance of this, stated with the estimate: 85%; the middle value lies on the limit itself.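

In this assay compound 3 gives > 63000 nM, a limit, and compound 1 is also a limit, so no step can be read between compound 1 and compound 3: the limit of > 63000 nM in this assay, at which 3 of the 3 values shown sit.

The compounds shown leave open whether hydroxy or methyl at this place has any bearing on inhibition.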